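Permeability of a sulfonamide series after replacing a nitrile chain

The source may hold more compounds than are shown below. What is called first, only, known or untested is meant among the compounds shown, and "the series" means these compounds.

Compound 1, `N#CC12CC(CN([C@H](CCC(F)(F)F)C(N)=O)S(=O)(=O)c3ccc(Cl)cc3)(C1)C2`, gives 30.2 10^-6 cm/s in an ADME assay on MDCKII-LE cells (Canis lupus familiaris) for permeability; on this read-out lower numbers stand for lower permeability and higher numbers for higher permeability.
Compound 2, `N#CCCCN([C@H](CCC(F)(F)F)C(N)=O)S(=O)(=O)c1ccc(Cl)cc1`, gives 27.6 10^-6 cm/s in this assay.
Compound 3, `C[C@]1(C#N)C[C@H](CN([C@H](CCC(F)(F)F)C(N)=O)S(=O)(=O)c2ccc(Cl)cc2)C1`, gives 21.8 10^-6 cm/s in this assay.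

Compound 2 holds the second highest of the three numbers, with compound 1 nearest and compound 3 furthest, and both of those gaps lie within the scatter. Compound 4, `NC(=O)[C@@H](CCC(F)(F)F)N(CC1(c2ncon2)CC1)S(=O)(=O)c1ccc(Cl)cc1`, has not yet been measured in this assay. Its change from compound 2 is 1-(1,2,4-oxadiazol-3-yl)cyclopropyl in place of 2-cyanoethyl on a saturated chain carbon bound to a sulfonamide nitrogen. The measured steps all touch the same position on the saturated chain carbon bound to the sulfonamide nitrogen: a 1.1-fold lower number from compound 1 to compound 2 (0.04 log units; within the scatter), a 1.4-fold lower number from compound 1 to compound 3 (0.14 log units; within the scatter) and a 1.3-fold lower number from compound 2 to compound 3 (0.10 log units; within the scatter). None of them moves beyond the scatter, but none brings in a second aromatic ring with three hetero atoms either, so they bear on compound 4 only loosely. Given that the counted change from the 2-cyanoethyl of compound 2 enters more heavy atoms and more hydrogen-bond acceptors, a modest downward step, a 1.5-fold lower number from compound 2 to compound 4 (0.19 log units; within the scatter), is expected in this assay. Compound 4 is therefore estimated at 18 10^-6 cm/s, with a range from 9 10^-6 cm/s to 32 10^-6 cm/s.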

Compound 4, apparent permeability: 16.4 10^-6 cm/s
Estimate against measurement, compound 4: 1.1-fold (0.04 log units) above, within the range that was stated.
By their numbers in this assay, from the lowest: compounds 4, 3, 2 and 1 (each within the scatter of the next).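

In this assay, 1-(1,2,4-oxadiazol-3-yl)cyclopropyl at the position on a saturated chain carbon bound to a sulfonamide nitrogen gives a 1.7-fold lower number from compound 2 to compound 4 (0.23 log units; within the scatter), a 1.3-fold lower number from compound 3 to compound 4 (0.12 log units; within the scatter) and a 1.8-fold lower number from compound 1 to compound 4 (0.27 log units; within the scatter). Going by these compounds alone, compound 4 is the first compound here without a nitrile and with a five-membered aromatic ring at this position, and all three of its steps stay within the scatter, so the position has now taken a group of a different kind with no step beyond the scatter. No supporting measurement bears on why this is so.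

On these data alone, the three-membered ring and the five-membered aromatic ring enter together, so their separate contributions remain open. Also open, as far as these compounds go, is whether an amine, a carboxylic acid or a longer chain at this position would give a step beyond the scatter.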